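Thiophen-2-yl to phenyl on the ethynyl group

This account rests on a few compounds, and the source may have more. Where it says the series, first, only, none or still open, it means among the compounds named here.

In a functional assay on NCI-H460 cells (Homo sapiens) for antiproliferative activity, with a stated time of 72 h (a higher number here means a weaker inhibitor, a lower number a stronger inhibitor), compound 1 `CCCC#Cc1cc([C@@H]2O[C@H](CO)[C@@H](O)[C@H]2O)n2ncnc(N)c12` gives 400 nM and compound 2 `Nc1ncnn2c([C@@H]3O[C@H](CO)[C@@H](O)[C@H]3O)cc(C#CC3CC3)c12` gives 80 nM in a modest step (a 5.0-fold lower number from compound 1 to compound 2 (0.70 log units; beyond the scatter)). Compound 3 `Nc1ncnn2c([C@@H]3O[C@H](CO)[C@@H](O)[C@H]3O)cc(C#Cc3cccs3)c12` stands highest of the three at 26600 nM after two large steps (a 67-fold higher number from compound 1 to compound 3 (1.82 log units; beyond the scatter) and a 330-fold higher number from compound 2 to compound 3 (2.52 log units; beyond the scatter)). Compound 4 `Nc1ncnn2c([C@@H]3O[C@H](CO)[C@@H](O)[C@H]3O)cc(C#Cc3ccccc3)c12` differs from compound 3 by phenyl in place of thiophen-2-yl on a triple-bonded carbon with phenyl in place of thiophen-2-yl on a triple-bonded carbon. Going by the values given here, no measured step exchanges one aromatic group for another, so those large steps only set the context. The expectation rests on compound 3 at 26600 nM as the sole aromatic comparator. No step beyond the scatter is expected (a 1.3-fold lower number from compound 3 to compound 4 (0.12 log units; within the scatter)). Compound 4 is estimated at 20000 nM (expected range 4000 nM to 60000 nM).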

Compound 4, half-maximal inhibitory concentration: 38500 nM
Compound 4: middle estimate off by 1.9-fold (0.28 log units), on the low side, within the range that was stated.
By their numbers in this assay, from the lowest: compound 2; then compound 1; then compounds 3 and 4 (each within the scatter of the next).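

In this assay, one aromatic group exchanged for another on the triple-bonded carbon stays within the scatter (a 1.4-fold higher number from compound 3 to compound 4 (0.16 log units; within the scatter)). Phenyl thus joins thiophen-2-yl, and both aromatic groups stand apart from the two non-aromatic groups, propyl (a 96-fold higher number from compound 1 to compound 4 (1.98 log units; beyond the scatter)) and cyclopropyl (a 480-fold higher number from compound 2 to compound 4 (2.68 log units; beyond the scatter)). Nothing available explains this separation.

From the compounds shown here alone, it remains open whether a longer alkyl chain or a chain ending in an amine would keep the numbers of compound 1 and compound 2. Going by these compounds, it is also open whether a pyridine ring would stay with the aromatic pair.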